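Ethyl to methyl ester on the benzofuran-pyrazoline series

A few compounds are considered here, and "the series" means these few. Any claim that something is new, unique, unknown or untested is made for them only; others in the source may bear on it.

The series shares a core in which a pyrazoline carrying a benzofuranyl group and an aryl group is joined to a thiazolidinone bearing an unsaturated ester. Compound 1 `CCOC(=O)/C=C1/SC(N2N=C(c3cc4ccccc4o3)CC2c2cccc(Br)c2)=NC1=O` holds a 3-bromophenyl group and an ethyl ester. In a functional assay on A549 cells (Homo sapiens) for antiproliferative activity, read by MTT assay, with a stated time of 96 h (on this read-out lower numbers stand for stronger inhibition and higher numbers for weaker inhibition), compound 1 gives only a limit, > 5 ug/mL. Compound 2 `CCOC(=O)/C=C1/SC(N2N=C(c3cc4ccccc4o3)CC2c2ccc(OC)cc2)=NC1=O` carries a 4-methoxyphenyl group in its place; in this assay compound 2 gives 1.21 ug/mL. Among the compounds with values here, that change is the only single step measured, an at least 4.1-fold lower number from compound 1 to compound 2 (0.61 log units; beyond the scatter). Compound 3 `COC(=O)/C=C1/SC(N2N=C(c3cc4ccccc4o3)CC2c2ccc(Cl)cc2)=NC1=O`, with a 4-chlorophenyl group and a methyl ester, gives 1.08 ug/mL in this assay, a number within the scatter of compound 2, so the two are not ordered. Compound 4 `COC(=O)/C=C1/SC(N2N=C(c3cc4ccccc4o3)CC2c2ccc(OC)cc2)=NC1=O` differs from compound 2 only at the ester: hydrogen in place of methyl on a saturated chain carbon bound to an oxygen next to a carbonyl group. Within the data shown here, no measured step covers this exchange, and the two measured values of compound 2 and compound 3 differ in two places at once. Compound 4 is therefore expected to sit at 1.1 ug/mL, between 0.5 ug/mL and 2.5 ug/mL, a step of a 1.1-fold lower number from compound 2 to compound 4 (0.04 log units; within the scatter) within the scatter.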

Compound 4, half-maximal inhibitory concentration: 2.45 ug/mL
Compound 4: the middle estimate sits 2.2-fold (0.35 log units) below what was measured; measured number inside the range.
By their numbers in this assay, from the lowest: compounds 3 and 2 (each within the scatter of the next); then compound 4. At a limit, above all of these: compound 1.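

In this assay, the ester position now has a step of its own: with the 4-methoxyphenyl group held fixed, ethoxycarbonyl to methoxycarbonyl gives a 2.0-fold higher number from compound 2 to compound 4 (0.31 log units; beyond the scatter), so this small change is not silent, although the step is modest. The same compound also isolates the aryl substituent with the methyl ester held fixed, a comparison the earlier values could not make, and methoxy in place of chloro on an aromatic carbon gives a 2.3-fold higher number from compound 3 to compound 4 (0.36 log units; beyond the scatter), also modest. Nothing measured here offers a reason for either step.

As far as these compounds go, each step rests on a single pair, so whether the ester step holds with other aryl groups remains open. From the compounds shown here alone, how a carboxylic acid, an amide or a longer chain such as a butyl ester would read at this position also remains open.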